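The source may report more compounds than this note shows. Statements on the series, on what has been measured and on what is new or still open speak of the compounds shown alone.

Measured compounds, with values from a functional assay on MCF7 cells (Homo sapiens) for antiproliferative activity, read by MTT assay, with a stated time of 72 h (a lower number here means a stronger inhibitor, a higher number a weaker inhibitor), as the read-out

Compound 1 `CN(c1ccccc1)S(=O)(=O)C1CC2OC1C(c1ccc(NC(=O)CCCCCCC(=O)O)cc1)=C2c1ccc(O)cc1` gives 63800 nM
Compound 2 `CN(c1ccccc1Cl)S(=O)(=O)C1CC2OC1C(c1ccc(NC(=O)CCCCCCC(=O)O)cc1)=C2c1ccc(O)cc1` gives 12800 nM
Compound 3 `CCN(c1ccc(C)cc1)S(=O)(=O)C1CC2OC1C(c1ccc(NC(=O)CCCCCCC(=O)O)cc1)=C2c1ccc(O)cc1` gives 42300 nM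

Compound 3 stands among the two higher numbers (the steps are a 1.5-fold lower number from compound 1 to compound 3 (0.18 log units; within the scatter) and a 3.3-fold higher number from compound 2 to compound 3 (0.52 log units; beyond the scatter)). Compound 4 `CCN(c1cccc(C)c1)S(=O)(=O)C1CC2OC1C(c1ccc(NC(=O)CCCCCCC(=O)O)cc1)=C2c1ccc(O)cc1` differs from it in one place (3-methylphenyl in place of 4-methylphenyl on a sulfonamide nitrogen), with 3-methylphenyl in place of 4-methylphenyl on a sulfonamide nitrogen. Among the measured compounds shown here, no measured step moves a methyl group, so no direct precedent exists. The nearest change, on the same part of the molecule, stayed within the scatter (a 1.5-fold lower number from compound 1 to compound 3 (0.18 log units; within the scatter)). Chloro in place of hydrogen on an aromatic carbon gave a modest step (a 5.0-fold lower number from compound 1 to compound 2 (0.70 log units; beyond the scatter)), which argues for a generous range. In this assay no step beyond the scatter is therefore expected, and the estimated step is small (a 1.1-fold lower number from compound 3 to compound 4 (0.05 log units; within the scatter)). For compound 4 the estimated value is 38000 nM (expected range 16000 nM to 80000 nM).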

Compound 4, half-maximal inhibitory concentration: 31800 nM
Compound 4: middle estimate off by 1.2-fold (0.08 log units), on the high side, within the range that was stated.
By their numbers in this assay, from the lowest: compound 2; then compounds 4, 3 and 1 (each within the scatter of the next).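

In this assay, 3-methylphenyl in place of 4-methylphenyl on a sulfonamide nitrogen gives a 1.3-fold lower number from compound 3 to compound 4 (0.12 log units; within the scatter), so moving the methyl group around this ring makes no change that can be told from the scatter. Among the compounds shown here, the combined change from the first compound to the new one also stays within the scatter, at a 2.0-fold lower number from compound 1 to compound 4 (0.30 log units; within the scatter), while the chloro compound remains apart, with a 2.5-fold higher number from compound 2 to compound 4 (0.40 log units; beyond the scatter). No measurement here explains these results. Going by these compounds, it remains open whether a methoxy group or an amine on this phenyl ring would shift the number.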